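Swapping the amine substituent: from pyrazinyl to 3-methoxybenzyl

A few compounds are considered here, and "the series" means these few. Any claim that something is new, unique, unknown or untested is made for them only; others in the source may bear on it.

Measured so far:
compound 1, `COCCNCc1c(-c2nnc(SC(C)C)n2-c2ccccc2)n(C)c2ccccc12`: 4.36
compound 2, `CC(C)Sc1nnc(-c2c(CNc3cnccn3)c3ccccc3n2C)n1-c1ccccc1`: 4.22

In a physicochemical assay for lipophilicity (a higher number here means a more lipophilic compound, a lower number a more polar compound), compound 2 gives 4.22, the lower of the two numbers, with compound 1 lying within the scatter of it. Compound 3, `COc1cccc(CNCc2c(-c3nnc(SC(C)C)n3-c3ccccc3)n(C)c3ccccc23)c1`, carries the change (3-methoxybenzyl in place of pyrazin-2-yl on an amine nitrogen). For the measured compounds named here, the only measured step at this position, a number 0.14 log units lower from compound 1 to compound 2 (within the scatter), stayed within the scatter, so it offers no direct guide. Since the entering group has more carbon atoms and a ring of carbon only, compound 3 is expected to move up in this assay by a number 0.78 log units higher from compound 2 to compound 3 (beyond the scatter), to an estimated 5, plausibly between 4.5 and 5.5.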

Compound 3, partition coefficient: 6.27
Compound 3: the middle estimate sits 1.27 log units below what was measured, outside the stated range (above it).
By their numbers in this assay, from the lowest: compounds 2 and 1 (each within the scatter of the next); then compound 3.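

In this assay, the amine nitrogen turns out to be a position where a single change can move the number well beyond the scatter: 3-methoxybenzyl in place of pyrazin-2-yl gives a number 2.05 log units higher from compound 2 to compound 3 (beyond the scatter), whereas the earlier step here stayed within it. Measured against the 2-methoxyethyl group, the same entering group gives a number 1.91 log units higher from compound 1 to compound 3 (beyond the scatter), so compound 3 stands clear of both earlier compounds. Nothing available accounts for the size of these steps. The compounds shown leave open whether the rise belongs to the benzyl ring or to its methoxy group, and how this assay would read for an unsubstituted benzyl or a longer alkyl chain on this nitrogen.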